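Iodo for Bromo: the Expected Next Step

This account rests on a few compounds, and the source may have more. Where it says the series, first, only, none or still open, it means among the compounds named here.

Two halogen variants of one core have been tested in a functional assay on the whole organism with Rattus norvegicus as the target; a higher number here means that more compound is needed for the effect, a lower number that less compound is needed. Compound 1, `Cc1cc(C)n2ncc(F)c2n1`, gives 80 mg/kg. Compound 2, `Cc1cc(C)n2ncc(Br)c2n1`, gives 20 mg/kg. Going by the values given here, the single step between them, a 4.0-fold lower number from compound 1 to compound 2 (0.60 log units; beyond the scatter), is the only comparison available, so compound 2 stands at the lowest of the two numbers, with compound 1 as its nearest neighbour at a higher value.

Compound 3, `Cc1cc(C)n2ncc(I)c2n1`, differs from compound 2 in one place: iodo in place of bromo on an aromatic carbon. Among the compounds with values here, the only measured step that bears on this change is a 4.0-fold lower number from compound 1 to compound 2 (0.60 log units; beyond the scatter), in which the exchange of fluoro for bromo went with a lower number. Within the data shown here, no measured step shows what the exchange of bromo for iodo does on this core, so the direction of the expectation is taken from that one step, while its size is kept smaller.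

Compound 3 is therefore expected to need a somewhat lower dose in this assay, an estimated step of a 2.0-fold lower number from compound 2 to compound 3 (0.30 log units; within the scatter). The estimated value for compound 3 is 10 mg/kg, with a range from 4 mg/kg to 30 mg/kg, a step that could still fall within the scatter.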

Compound 3, minimum effective dose: 120 mg/kg
Compound 3: middle estimate off by 12-fold (1.08 log units), on the low side; the whole stated range lies below it.
By their numbers in this assay, from the lowest: compound 2; then compounds 1 and 3 (each within the scatter of the next).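

In this assay, the halogens on this aromatic carbon do not follow one direction: a 4.0-fold lower number from compound 1 to compound 2 (0.60 log units; beyond the scatter) is reversed by a 6.0-fold higher number from compound 2 to compound 3 (0.78 log units; beyond the scatter), so the change from bromo to iodo gives up the whole gain seen with bromo. The remaining comparison, a 1.5-fold higher number from compound 1 to compound 3 (0.18 log units; within the scatter), lies within the scatter, which leaves the fluoro and iodo compounds indistinguishable and makes compound 2 the only one of the three that stands apart. Nothing available offers an explanation for this turn in direction.

The compounds shown leave open whether chloro on the same aromatic carbon would fall with compound 2 or with compound 1 and compound 3, which would show how narrowly the low dose is tied to bromo. They also leave open whether compound 2, with its 20 mg/kg, marks a result particular to halogens, since a nitrile, an amine or a methoxy group at this place could either match that dose or fall well away from it.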